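A few compounds are considered here, and "the series" means these few. Any claim that something is new, unique, unknown or untested is made for them only; others in the source may bear on it.

Of the compounds shown here, two have been measured in a functional assay on HL-60 cells (Homo sapiens) for cytotoxicity, read by luminescence and CellTiter-Glo, with a stated time of 3 days; on this read-out lower numbers stand for stronger inhibition and higher numbers for weaker inhibition. Compound 1, `N#Cc1ccc(NC(=O)c2cc(-c3cccnc3)ccc2O)cc1`, gives 7960 nM in this assay. Compound 2, `N#Cc1cccc(NC(=O)c2cc(F)ccc2O)c1`, gives 7750 nM in this assay. Compound 1 holds the higher of the two numbers on paper, but the gap to compound 2 is within the usual scatter of repeated measurements, so the two compounds cannot be separated on this evidence; both sit in a range that stands for weak inhibition of cell growth.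

The next compound, compound 3, is `N#Cc1ccc(NC(=O)c2ccccc2O)cc1`. It differs from compound 1 in one place: hydrogen in place of pyridin-3-yl on an aromatic carbon. The shared core of the two compounds, with its amide, hydroxy group and nitrile, is kept unchanged.

Going by the values given here, no measured pair that differs in only one place is available, so the size of this step cannot be read from earlier data. Given that compound 2 carries a small group at the corresponding place and gives 7750 nM, the step of a 1.4-fold higher number from compound 1 to compound 3 (0.14 log units; within the scatter) is expected to be small, pointing to a slightly higher number, and may not exceed the scatter. Compound 3 is therefore estimated at 11000 nM, with a range from 4000 nM to 30000 nM.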

Compound 3, half-maximal inhibitory concentration: 4620 nM
Estimate against measurement, compound 3: 2.4-fold (0.38 log units) above; low and high end bracket the measured number.
By their numbers in this assay, from the lowest: compounds 3, 2 and 1 (each within the scatter of the next).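

In this assay, going by these compounds alone, this step gives the first direct reading of the position on the aromatic carbon para to a hydroxy group: replacing pyridin-3-yl with hydrogen gives a 1.7-fold lower number from compound 1 to compound 3 (0.24 log units; within the scatter). At this level of activity, the pyridin-3-yl group therefore has no effect that can be told apart from ordinary measurement scatter, so neither its presence nor its absence at this place can be said to matter. Nothing measured on these compounds explains this result.

Only hydrogen and pyridin-3-yl can be compared directly at this position, so the pair gives no sense of how other groups would behave there, and a lack of effect from one aromatic ring does not show that the position is insensitive to every change. On these data alone, whether an amine, a carboxylic acid or a longer chain such as butyl at this place would move the number in this assay beyond the scatter remains open.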